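The source may hold more compounds than are shown below. What is called first, only, known or untested is meant among the compounds shown, and "the series" means these compounds.

In an assay (Canis lupus familiaris) for binding affinity to platelet-activating factor receptor (Homo sapiens), read by radioligand binding (on this read-out higher numbers stand for weaker inhibition and lower numbers for stronger inhibition), three compounds have been measured. Compound 1 `COc1ccc(-c2ccc(C(=O)NCCCCc3cccnc3)cc2OC)cc1OC` gives 300 nM and stands at the highest, weakest end of the three numbers. Among the measured compounds shown here, compound 2 `COc1cccc(-c2ccc(C(=O)N[C@H](C)CCCc3cccnc3)cc2)c1` gives 20 nM, and compound 3 `CCCCc1cc(C(=O)N[C@H](C)CCCc2cccnc2)ccc1-c1ccc(OC)c(OC)c1` gives 4 nM; both differ from compound 1 in more than one place, so their numbers show only that compound 1 is the weakest of the three, with each gap to it beyond the usual scatter.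

For the measured compounds named here, compound 4 `COc1ccc(-c2ccc(C(=O)NCCCCc3cccnc3)cc2Br)cc1OC` is the one change away from compound 1: bromo in place of methoxy on an aromatic carbon. Going by the values given here, no single-change step among the measured compounds speaks to this swap. Compound 3 carries no methoxy on the shared core at all and is the strongest of the set, but its several other differences from compound 1 leave the weight of that one position unsettled.

On this basis, a modest gain is expected rather than a large one, with the chance that the swap changes nothing beyond the scatter. Compound 4 is estimated at 150 nM, within a range from 50 nM to 500 nM. That estimate means a step of a 2.0-fold lower number from compound 1 to compound 4 (0.30 log units; within the scatter), expected to be small and toward stronger binding.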

Compound 4, half-maximal inhibitory concentration: 220 nM
Beside the measured number, compound 4's estimate is 1.5-fold (0.17 log units) below it; the measured number falls inside the stated range.
By their numbers in this assay, from the lowest: compound 3; then compound 2; then compounds 4 and 1 (each within the scatter of the next).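

The one-change step in this assay gives a 1.4-fold lower number from compound 1 to compound 4 (0.13 log units; within the scatter), so on the core of compound 1 this position accepts bromo in place of methoxy with no difference that can be told from the scatter. Bromo brings one heavy atom where methoxy has two and no hydrogen-bond acceptor where methoxy has one, so neither the carbon and oxygen of the methoxy nor its acceptor is needed at this place to keep the number of compound 1 within the scatter. The data offer no independent measurement that would account for this result.

On these data alone, what remains open is whether other groups at this position, such as chloro, hydroxyl, an amine or a carboxylic acid, would also leave the number within the scatter, since this single step covers only methoxy and bromo. As far as these compounds go, it also remains open whether the same swap would read alike on a core carrying a different amide chain, as this step comes from the core of compound 1 alone.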